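A few compounds are considered here, and "the series" means these few. Any claim that something is new, unique, unknown or untested is made for them only; others in the source may bear on it.

Measured compounds:
compound 1 `Cc1ccc(C2(CNC(=O)Nc3c(C(C)C)cccc3C(C)C)CCCC2)cc1` — 25 nM
compound 2 `COc1cccc(C2(CNC(=O)Nc3c(C(C)C)cccc3C(C)C)CCCC2)c1` — 13 nM
compound 3 `CC(C)c1cccc(C(C)C)c1NC(=O)NCC1(c2cccc(N(C)C)c2)CCCC1` — 33 nM

In an assay on microsomes for inhibition of acyl-CoA:cholesterol acyltransferase (Oryctolagus cuniculus) (on this read-out higher numbers stand for weaker inhibition and lower numbers for stronger inhibition), compound 1 stands second highest of the three numbers. Compound 3 is nearest to it and compound 2 furthest, yet both steps, a 1.9-fold lower number from compound 1 to compound 2 (0.28 log units; within the scatter) and a 1.3-fold higher number from compound 1 to compound 3 (0.12 log units; within the scatter), stay within the scatter. Among the measured compounds shown here, the only step beyond the scatter is a 2.5-fold higher number from compound 2 to compound 3 (0.40 log units; beyond the scatter), a modest one, and it concerns an exchange of one substituent for another on an aromatic carbon.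

Compound 4 `CC(C)c1cccc(C(C)C)c1NC(=O)NCC1(c2ccc(NCCO)cc2)CCCC1` is not yet measured. Against compound 1 it shows ((2-hydroxyethyl)amino in place of methyl on an aromatic carbon). For the measured compounds named here, no measured step touches this position or this group; the nearest analogy is the substituent exchange on an aromatic carbon between compound 2 and compound 3, which was modest. Across the three measured compounds the aryl group on the saturated ring carbon has moved the number little, so the step to compound 4 is expected to be small as well, if anything toward a higher number. Compound 4 is therefore estimated at 40 nM, within 12 nM to 130 nM, the expected step being a 1.6-fold higher number from compound 1 to compound 4 (0.20 log units; within the scatter).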

Compound 4, half-maximal inhibitory concentration: 25 nM
For compound 4 the middle estimate is 1.6-fold (0.20 log units) above the measured one; measured number inside the range.
By their numbers in this assay, from the lowest: compounds 2, 1, 4 and 3 (each within the scatter of the next, the first and the last beyond it).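

In this assay, among the compounds shown here, (2-hydroxyethyl)amino on an aromatic carbon para to a large group gives no change at the digits printed from compound 1 to compound 4 (within the scatter), so this position accepts a larger chain bearing hydrogen-bond donors, where the earlier compounds showed only methyl. The other two comparisons, a 1.3-fold lower number from compound 3 to compound 4 (0.12 log units; within the scatter) and a 1.9-fold higher number from compound 2 to compound 4 (0.28 log units; within the scatter), also stay within the scatter, so the new aryl group cannot be separated from either earlier aryl group, and none of the aryl exchanges involving compound 4 moves the number beyond it. No accompanying data bear on why the number holds at this position.

Open, going by these compounds, is how far this tolerance extends, for example to a carboxylic acid or a longer chain such as (4-hydroxybutyl)amino at the same position. Also open, on these data alone, is whether the hydroxyl or the amine nitrogen of the (2-hydroxyethyl)amino group matters, which a simple ethylamino group could test.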